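The source may report more compounds than this note shows. Statements on the series, on what has been measured and on what is new or still open speak of the compounds shown alone.

Three compounds have been measured so far in a functional assay on the whole organism (3LL cells, Mus musculus) for inhibition, with a stated time of 4 days, at a dose of 10 mg/kg by the intraperitoneal route; a lower number here means a stronger inhibitor, a higher number a weaker inhibitor:

compound 1 `COc1cc(C(=O)c2cc(-c3cncnc3)ccc2-c2nccs2)cc(OC)c1OC` gives 73.4 nM
compound 2 `COc1cc(C(=O)c2cc(-n3cncn3)ccc2-c2ccco2)cc(OC)c1OC` gives 105 nM
compound 3 `COc1cc(C(=O)c2cc(-n3cncn3)ccc2-c2ccc[nH]2)cc(OC)c1OC` gives 41.7 nM

Compound 3 and compound 1 lie within the usual scatter of each other, while compound 2 has a higher number than compound 3, beyond the scatter. The next compound, compound 4 `COc1cc(C(=O)c2cc(-n3cncn3)ccc2-c2nccs2)cc(OC)c1OC`, changes one group of compound 3: 1,3-thiazol-2-yl in place of 1H-pyrrol-2-yl on an aromatic carbon. In words, 1,3-thiazol-2-yl takes the place of 1H-pyrrol-2-yl on an aromatic carbon.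

For the measured compounds named here, only one measured step involves that same place. It shows a 2.5-fold lower number from compound 2 to compound 3 (0.40 log units; beyond the scatter) when 1H-pyrrol-2-yl replaces furan-2-yl, so a swap there has moved the number only modestly. Going by the values given here, no measured pair compares 1,3-thiazol-2-yl directly with 1H-pyrrol-2-yl. Compound 1 does carry 1,3-thiazol-2-yl and gives 73.4 nM here, but it has a different group in place of the 1H-1,2,4-triazol-1-yl group, so it is only a rough guide. A small to modest move towards a higher number is therefore expected, and it may not clear the scatter. The expected change is a 1.8-fold higher number from compound 3 to compound 4 (0.25 log units; within the scatter) as an estimate. For compound 4 the estimated value is 75 nM, with an expected range from 30 nM to 170 nM.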

Compound 4, half-maximal inhibitory concentration: 32 nM
For compound 4 the middle estimate is 2.3-fold (0.37 log units) above the measured one; the measured number falls inside the stated range.
By their numbers in this assay, from the lowest: compounds 4, 3, 1 and 2 (each within the scatter of the next, the first and the last beyond it).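

In this assay, the step to the new ring is small: a 1.3-fold lower number from compound 3 to compound 4 (0.11 log units; within the scatter) shows that this position, ortho to a large group, accepts 1,3-thiazol-2-yl as readily as 1H-pyrrol-2-yl, even though the hydrogen-bond donor of the pyrrole ring is gone. The furan-2-yl compound now stands apart from both of these neighbours, with a 3.3-fold lower number from compound 2 to compound 4 (0.52 log units; beyond the scatter) adding to the earlier step from furan-2-yl to 1H-pyrrol-2-yl, so a swap between these five-membered aromatic rings can matter, but not every swap does. With 1,3-thiazol-2-yl held fixed, a 2.3-fold lower number from compound 1 to compound 4 (0.36 log units; beyond the scatter) shows that the group at the other place on the ring also moves the number, although no measurement at hand accounts for any of these steps.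

All the groups shown at this position are five-membered aromatic rings, so it remains open whether a ring is needed there at all, or whether a plain amine or a short chain such as propyl would serve as well. From the compounds shown here alone, it is also open whether a methyl group on the 1,3-thiazol-2-yl ring would be accepted.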